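This account rests on a few compounds, and the source may have more. Where it says the series, first, only, none or still open, it means among the compounds named here.

Within the series, compound 1 `CCOC(=O)c1c(-c2cc3ccccc3oc2=O)nn(-c2ccccc2)c1C(=O)OCC` gives 100000 nM in a functional assay on HeLa cells (Homo sapiens) for cytotoxicity, read by MTT assay, with a stated time of 48 h (a lower number here means a stronger inhibitor, a higher number a weaker inhibitor), and compound 2 `CCOC(=O)c1c(-c2cc3ccc(OC)cc3oc2=O)nn(-c2ccccc2)c1C(=O)OCC` gives 140000 nM in this assay; the step of a 1.4-fold higher number from compound 1 to compound 2 (0.15 log units; within the scatter) is the only one measured so far. Compound 2 therefore holds the highest of the two numbers, with compound 1 nearest, inside the scatter.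

Compound 3 `CCOC(=O)c1c(-c2cc3ccc(OCC=C(C)C)cc3oc2=O)nn(-c2ccccc2)c1C(=O)OCC` differs from compound 2 by 2-methylprop-1-en-1-yl in place of hydrogen on a saturated chain carbon bound to an oxygen on an aromatic ring. Among the compounds with values here, the one step that bears on it, a 1.4-fold higher number from compound 1 to compound 2 (0.15 log units; within the scatter), showed that changing this same oxygen-bearing position left this assay essentially unmoved. On that basis no step beyond the scatter is expected, a 1.1-fold lower number from compound 2 to compound 3 (0.03 log units; within the scatter). Compound 3 is accordingly estimated at 130000 nM, between 50000 nM and 350000 nM.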

Compound 3, half-maximal inhibitory concentration: 130000 nM
Compound 3: middle estimate and measured number agree at the digits printed, and the stated range covers the measured number.
By their numbers in this assay, from the lowest: compounds 1, 3 and 2 (each within the scatter of the next).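

Replacing the methyl on this oxygen with 3-methylbut-2-en-1-yl gives a 1.1-fold lower number from compound 2 to compound 3 (0.03 log units; within the scatter) in this assay, and adding (3-methylbut-2-en-1-yl)oxy to the shared core gives a 1.3-fold higher number from compound 1 to compound 3 (0.11 log units; within the scatter) in the same assay. The position therefore carries a chain with a double bond as well as methoxy, with no step beyond the scatter. Nothing available explains this flat result. As far as these compounds go, whether an amine or a carboxylic acid at this position would produce a step beyond the scatter stays open.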